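Cytotoxicity notes: aromatic versus alkyl substituent on the core

The source may report more compounds than this note shows. Statements on the series, on what has been measured and on what is new or still open speak of the compounds shown alone.

Compound 2 `CCC(CC)c1ccc2c(NCCCNCc3ccco3)ccnc2c1` carries a pentan-3-yl group on the shared core. Among the compounds with values here, in an ADME assay on HepG2 cells (Homo sapiens) for cytotoxicity, read by luminescence, CellTiter-Glo and ATP content, with a stated time of 72 h (on this read-out lower numbers stand for an effect already at smaller amounts and higher numbers for an effect only at larger amounts of compound), compound 2 gives 6760 nM, the highest of the two numbers measured so far. Its nearest neighbour is compound 1 `CC(C)(C)c1ccc(-c2ccc3c(NCCCNCc4ccco4)ccnc3c2)cc1`, which in this assay gives 3150 nM. Within the data shown here, the only measured step is a 2.1-fold higher number from compound 1 to compound 2 (0.33 log units; beyond the scatter), a modest change yet beyond the scatter, with the substituent that has no ring standing at the higher number.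

Compound 3 `c1coc(CNCCCNc2ccnc3cc(-c4cccc5ccccc45)ccc23)c1` is the next member and not yet measured. It differs from compound 2 in one place: naphthalen-1-yl in place of pentan-3-yl on an aromatic carbon. The step that bears on this change is a 2.1-fold higher number from compound 1 to compound 2 (0.33 log units; beyond the scatter), where a substituent with an aromatic ring gave way to one with no ring. Restoring a substituent built of two six-membered aromatic rings is therefore expected to run the other way, by a modest amount, as an expected 1.8-fold lower number from compound 2 to compound 3 (0.25 log units; within the scatter). Compound 3 is accordingly estimated at about 3800 nM in this assay, with an expected range from 1800 nM to 8000 nM.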

Compound 3, half-maximal effective concentration: 5600 nM
Compound 3: the middle estimate sits 1.5-fold (0.17 log units) below what was measured, within the range that was stated.
By their numbers in this assay, from the lowest: compounds 1, 3 and 2 (each within the scatter of the next, the first and the last beyond it).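

In this assay naphthalen-1-yl gives a 1.2-fold lower number from compound 2 to compound 3 (0.08 log units; within the scatter) and also a 1.8-fold higher number from compound 1 to compound 3 (0.25 log units; within the scatter) when set against 4-(tert-butyl)phenyl, so at this position it cannot be told apart from either group. The gap between compound 1 and compound 2 therefore does not sort simply by ring and no ring: compound 3 carries 2 six-membered aromatic rings of carbon only, yet stands within the scatter of compound 2, which has no ring, and goes against any such pattern. Across these three compounds, this aromatic carbon of the shared core carries a branched alkyl group, a substituted phenyl group and a fused aromatic group, and only compound 1 and compound 2 lie beyond the scatter of each other; no measurement at hand explains these numbers.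

From the compounds shown here alone, whether a substituent holding an amine, a carboxylic acid or a longer straight alkyl chain at this position would stand beyond the scatter of all three compounds remains open. Going by these compounds, the three compounds also share the same side chain on the core, so what a change there would do in this read-out remains open too.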